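A few compounds are considered here, and "the series" means these few. Any claim that something is new, unique, unknown or untested is made for them only; others in the source may bear on it.

Measured so far in a functional assay on the whole organism with Mus musculus as the target; a lower number here means that less compound is needed, a higher number that more compound is needed for the effect:
compound 1, `CCCS(=O)(=O)N1CCN(C(C)=O)CC1`: 0.1 mg/kg
compound 2, `CCCS(=O)(=O)N1CCCN(C(C)=O)CC1`: > 10 mg/kg

In this assay compound 1 gives 0.1 mg/kg. For compound 2 this assay returns only a limit, > 10 mg/kg, not a number. Compound 2 therefore stands at the limit of > 10 mg/kg in this assay, at which 1 of the 2 values shown sits, and no value for it is known. Among the measured compounds shown here, no step between the two measured compounds is computed; their two results show only that compound 1 has a number and compound 2 has none.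

Compound 3, `CCCS(=O)(=O)N1CCCN(C(=O)CC)CC1`, is not yet measured. It differs from compound 2 by methyl in place of hydrogen on a saturated chain carbon bound to a carbonyl carbon, acetyl to propanoyl. Because compound 2 sits at the limit of > 10 mg/kg in this assay, at which 1 of the 2 values shown sits, the expected step is a step that the limit leaves unreadable from compound 2 to compound 3, none beyond the scatter, read against a limit. Compound 3 is expected to give 20 mg/kg, with a range from 5 mg/kg to 100 mg/kg, most probably again as a limit only.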

Compound 3, minimum effective dose: > 10 mg/kg
Compound 3 ended at the assay's limit; the forecaster's own chance of this, stated with the estimate: 75%; the middle value is on the limit's open side.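

Compound 2 and compound 3 both sit at a limit rather than at a number, so no step from acetyl to propanoyl can be read: the limit of > 10 mg/kg in this assay, at which 2 of the 3 values shown sit.

The compounds shown leave open whether acetyl to propanoyl changes the minimum effective dose at all.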